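From pyridin-3-yl to pyridin-4-yl at the assay limit

The compounds below may be only part of what the source reports. "The series", "measured", "known", "first", "only" and "open" are said of these compounds alone.

Of the compounds shown here, three sharing one core have been tested in an ADME assay on MDBK cells (Bos taurus) for cytotoxicity (a lower number here means that less compound is tolerated, a higher number that more compound is tolerated), so far. Compound 1 (`Fc1cccc(F)c1Cn1ccc2nc(-c3ccccc3)nc-2c1`) reads > 100000 nM and this is a limit of the assay, not a number. Compound 2 (`Brc1cccc(Cn2ccc3nc(-c4ccccc4)nc-3c2)c1`) gives a true number of 85000 nM in this test. Compound 3 (`c1ccc(-c2nc3ccn(Cc4cccnc4)cc-3n2)cc1`) reads > 100000 nM and this too is only a limit. The series thus rests largely on the limit of > 100000 nM in this assay, at which 2 of the 3 values shown sit, and compound 3 has no exact position within it.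

Compound 4 (`c1ccc(-c2nc3ccn(Cc4ccncc4)cc-3n2)cc1`) carries pyridin-4-yl in place of pyridin-3-yl on a saturated chain carbon bound to an aromatic nitrogen with the same atoms joined differently.

Three measured changes at this place bear on it. The first is an at least 1.1-fold lower number from compound 1 to compound 2 (0.07 log units; that floor lies within the scatter) and the second is an at least 1.1-fold higher number from compound 2 to compound 3 (0.07 log units; that floor lies within the scatter) while the third, a step that the two limits leave unreadable from compound 1 to compound 3, cannot be sized. None of them is shown to exceed the scatter, even though they swap quite different groups, so no step beyond the scatter is expected in either direction. The expected change is a number no higher from compound 3 to compound 4 (the limit leaves the size open) as an estimate only. For compound 4 the estimated value is 100000 nM with an expected range from 60000 nM to 160000 nM and a report as a limit alone would be no surprise.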

Compound 4, half-maximal cytotoxic concentration: > 100000 nM
Compound 4: only a limit was reported; the forecaster's own chance of this, stated with the estimate: 70%; the middle value lies on the limit itself.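

In this assay compound 4 puts a second pyridine isomer on a saturated chain carbon bound to an aromatic nitrogen, and its reading is a limit, not a number, just as the reading of compound 3 is. The steps that join two limits cannot be read, so neither the move from pyridin-3-yl to pyridin-4-yl nor the replacement of 2,6-difluorophenyl by pyridin-4-yl has a size. The one step that can be read is an at least 1.1-fold higher number from compound 2 to compound 4 (0.07 log units; that floor lies within the scatter), which leaves compound 2 as the only true number in the series, and the series now rests even more on a single ceiling: the limit of > 100000 nM in this assay, at which 3 of the 4 values shown sit.

The compounds shown leave open whether compound 3 and compound 4 differ at all, since neither has an exact position, and where compound 1, compound 3 and compound 4 would fall if the assay reached further. Also open, on these data alone, is whether a different group at this place, such as a morpholine, a carboxylic acid or a longer chain carrying the pyridin-4-yl, would give a true number as compound 2 does.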